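Butyrylamide to valerylamide on the aminopyrimidine series

The source may hold more compounds than are shown below. What is called first, only, known or untested is meant among the compounds shown, and "the series" means these compounds.

Compound 1 `Nc1ncc(-c2cccc(Cl)c2)c(-c2ccccc2)n1` carries a free amino group on the shared core. In an assay on CHO cells for displacement of a labelled ligand from adenosine receptor A1 (Homo sapiens), read by scintillation counting, with a stated time of 1 h, tested at 1 uM (on this read-out lower numbers stand for less inhibition and higher numbers for more inhibition at the one concentration tested (going by the name of the read-out)), compound 1 gives > 80%, which is a limit of the assay and not a number. Compound 2 `CCCC(=O)Nc1ncc(-c2cccc(Cl)c2)c(-c2ccccc2)n1` is the butanoyl amide of the same core. In this assay compound 2 gives > 80%, again a limit of the assay rather than a number. The step that the two limits leave unreadable from compound 1 to compound 2 therefore cannot be sized; both values sit at the limit of > 80% in this assay, at which 2 of the 2 values shown sit.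

Compound 3 `CCCCC(=O)Nc1ncc(-c2cccc(Cl)c2)c(-c2ccccc2)n1` has not yet been measured. It differs from compound 2 by methyl in place of hydrogen on a saturated chain carbon, three bonds along the chain from a carbonyl carbon. Within the data shown here, only the step from compound 1 to compound 2 bears on this, and it is unreadable from its two limits; it shows, at most, that adding the propylcarbonyl chain did not pull the read-out below the limit. On that basis the change to compound 3 is expected to leave the read-out at or near the same limit, a step that the limit leaves unreadable from compound 2 to compound 3. Compound 3 is thus estimated at 88%, in the range 72% to 100%, most likely reported again as a limit.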

Compound 3, a percentage reported as inhibition, at one concentration (the size of the read-out at that concentration, not a potency): 52%
Estimate against measurement, compound 3: 36 percentage points above; measured number below the stated range.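

In this assay, among these compounds, methyl in place of hydrogen on a saturated chain carbon, three bonds along the chain from a carbonyl carbon, gives the first step that can be read: a number at least 28 percentage points lower from compound 2 to compound 3 (beyond the scatter). The butylcarbonyl amide also separates from the free amino group, with a number at least 28 percentage points lower from compound 1 to compound 3 (beyond the scatter), so the read-out at this end of the amide chain responds to a single added methyl, which the unreadable step from the free amine to the propylcarbonyl amide could not show. Both steps are bounds and not exact sizes, because each starts from a limit: the limit of > 80% in this assay, at which 2 of the 3 values shown sit.

Open, as far as these compounds go, is whether a longer chain such as pentylcarbonyl lowers the read-out further or whether the loss levels off. Also open, from the compounds shown here alone, is how a branched chain, or an amine or carboxylic acid at the chain end, would read at this position.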